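Phenyl for methyl on the shared core: compound 4

The source may hold more compounds than are shown below. What is called first, only, known or untested is meant among the compounds shown, and "the series" means these compounds.

Measured so far in a functional assay on AGS cells (Homo sapiens) for cytotoxicity, read by MTT assay, with a stated time of 48 h; on this read-out lower numbers stand for stronger inhibition and higher numbers for weaker inhibition:
- compound 1 `Cc1nc2c3ccccc3ccc2c2nc3c(ccc4ccccc43)c(-c3ccc(O)cc3)c12` gives 14200 nM.
- compound 2 `Cc1ccc(-c2c3ccc4ccccc4c3nc3c2c(C)nc2c4ccccc4ccc32)cc1` gives only a limit of the assay, > 80000 nM.
- compound 3 `Cc1nc2c3ccccc3ccc2c2nc3c(ccc4ccccc43)c(C)c12` gives only a limit of the assay, > 80000 nM.

Compound 3 thus has no number in this assay, only a limit; two of the three values sit at the limit of > 80000 nM in this assay, at which 2 of the 3 values shown sit, and compound 1 alone gives a number. Compound 4 `Cc1nc2c3ccccc3ccc2c2nc3c(ccc4ccccc43)c(-c3ccccc3)c12` differs from compound 3 by phenyl in place of methyl on an aromatic carbon. For the measured compounds named here, two measured steps bear on this change: an at least 5.6-fold higher number from compound 1 to compound 3 (0.75 log units; beyond the scatter), and a step that the two limits leave unreadable from compound 2 to compound 3. Compound 4 carries the phenyl without the hydroxy of compound 1. Compound 2, which carries a 4-methylphenyl, gives only a limit. A partial return toward compound 1 is possible, but a limit for compound 4 is about as likely. Compound 4 is therefore expected near the limit, at 60000 nM (range 20000 nM to 160000 nM), an expected step of an at least 1.3-fold lower number from compound 3 to compound 4 (0.12 log units; that floor lies within the scatter).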

Compound 4, half-maximal inhibitory concentration: > 80000 nM
Compound 4 ended at the assay's limit; the forecaster's own chance of this, stated with the estimate: 55%; at least 1.3-fold (0.12 log units) between middle value and limit.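

In this assay, hydrogen in place of hydroxy on the phenyl gives an at least 5.6-fold higher number from compound 1 to compound 4 (0.75 log units; beyond the scatter), so the phenyl at this position does not by itself bring back the activity of compound 1. Among the compounds with a phenyl here, only the one with the hydroxy gives a number, and the steps among compound 2, compound 3 and compound 4 cannot be read. The series now rests mostly on limits: the limit of > 80000 nM in this assay, at which 3 of the 4 values shown sit.

From the compounds shown here alone, whether an amine or a methoxy in place of the hydroxy would also give a number remains open. So does whether the hydroxy would give a number on a group other than phenyl at this position.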